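Chloro for hydrogen, carried onto a second amine variant

This account rests on a few compounds, and the source may have more. Where it says the series, first, only, none or still open, it means among the compounds named here.

Compound 1 `O=c1c(CSC(=S)N2CCCC2)coc2ccccc12` gives 6000 nM in a functional assay on LM7 cells (Homo sapiens) for antiproliferative activity, read by MTT assay, with a stated time of 72 h; on this read-out lower numbers stand for stronger inhibition and higher numbers for weaker inhibition. Compound 2 `O=c1c(CSC(=S)N2CCCC2)coc2cc(Cl)ccc12` differs from compound 1 by chloro in place of hydrogen on an aromatic carbon; in this assay compound 2 gives 2600 nM, the step being a 2.3-fold lower number from compound 1 to compound 2 (0.36 log units; beyond the scatter). Compound 3 `CC(C)N(C(=S)SCc1coc2ccccc2c1=O)C(C)C` differs from compound 1 by diisopropylamino in place of pyrrolidin-1-yl on a thiocarbonyl carbon; in this assay compound 3 gives 21900 nM, the step being a 3.7-fold higher number from compound 1 to compound 3 (0.56 log units; beyond the scatter). Compound 4 `CC(C)N(C(=S)SCc1coc2cc(Cl)ccc2c1=O)C(C)C` stands to compound 3 as compound 2 stands to compound 1, by chloro in place of hydrogen on an aromatic carbon, with the place described in identical words, so this is the same change, occurring twice among these compounds. Among the measured compounds shown here, for compound 4 the step is expected to be a 2.3-fold lower number from compound 3 to compound 4 (0.36 log units; beyond the scatter), resting on the single measured instance of the change because that instance is a 2.3-fold lower number from compound 1 to compound 2 (0.36 log units; beyond the scatter). Compound 4 is therefore estimated at 9500 nM, with a range from 4500 nM to 20000 nM.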

Compound 4, half-maximal inhibitory concentration: > 25000 nM
Compound 4: no number, only a limit; the forecaster's own chance of this, stated with the estimate: 10%; at least 2.6-fold (0.42 log units) between middle value and limit.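

In this assay compound 4 gives > 25000 nM, which is a limit of the assay and not a number. With diisopropylamino in place of pyrrolidin-1-yl, chloro in place of hydrogen gives an at least 1.1-fold higher number from compound 3 to compound 4 (0.05 log units; that floor lies within the scatter), so the lower number seen on the core of compound 1 does not recur here, although the size of any gap between the two steps cannot be read: the same change on two cores in this assay, a 2.3-fold lower number (0.36 log units; beyond the scatter) from compound 1 to compound 2 and an at least 1.1-fold higher number (0.05 log units; that floor lies within the scatter) from compound 3 to compound 4; the limit leaves it open whether they differ The amine change, read on the chloro core, gives an at least 9.6-fold higher number from compound 2 to compound 4 (0.98 log units; beyond the scatter), and it keeps the direction seen without chloro, with its size likewise unsettled: the same change on two cores in this assay, a 3.7-fold higher number (0.56 log units; beyond the scatter) from compound 1 to compound 3 and an at least 9.6-fold higher number (0.98 log units; beyond the scatter) from compound 2 to compound 4; the limit leaves it open whether they differ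

On these data alone, how far compound 4 lies past its limit stays open. So does whether chloro lowers the number with other amines on the thiocarbonyl carbon, such as piperidin-1-yl or morpholin-4-yl.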